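Removing the thioether arm: from compound 3 to compound 4

The source may report more compounds than this note shows. Statements on the series, on what has been measured and on what is new or still open speak of the compounds shown alone.

Measured compounds:
compound 1 `Cc1cc(Nc2ccc(C(=O)/C=C/c3cccc(Br)n3)cc2)n2nc(SCc3ccc([N+](=O)[O-])cc3)nc2n1` gave 91.6%
compound 2 `Cc1cc(Nc2ccc(C(=O)/C=C/c3cccc(Br)n3)cc2)n2nc(SCc3ccc(C(F)(F)F)cc3)nc2n1` gave 96.6%
compound 3 `Cc1cc(Nc2ccc(C(=O)/C=C/c3cccc(Br)n3)cc2)n2nc(SCc3nc4ccccc4[nH]3)nc2n1` gave 94.4%

All three values come from a functional assay on MGC-803 cells (Homo sapiens) for inhibition, read by sulforhodamine B assay, with a stated time of 72 h, tested at 10 uM; a higher number here means more inhibition at the concentration tested (going by the name of the read-out), a lower number less inhibition. Compound 3 stands second highest of the three numbers in this assay: its nearest neighbour is compound 2, a step of a number 2.2 percentage points lower from compound 2 to compound 3 (within the scatter), and its furthest is compound 1, a step of a number 2.8 percentage points higher from compound 1 to compound 3 (within the scatter). Both steps are within the scatter, so the three compounds cannot be ordered against each other.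

Compound 4 `Cc1cc(Nc2ccc(C(=O)/C=C/c3cccc(Br)n3)cc2)n2ncnc2n1` differs from compound 3 by hydrogen in place of ((1H-benzimidazol-2-yl)methyl)sulfanyl on an aromatic carbon. Among the compounds with values here, none of the measured steps covers this change. The steps of a number 5 percentage points higher from compound 1 to compound 2 (within the scatter) and a number 2.8 percentage points higher from compound 1 to compound 3 (within the scatter) only exchange one group for another at the end of the same arm, and each stays within the scatter, so they show that the identity of that terminal group barely matters, but they say nothing about removing the whole arm. Within the data shown here, the expectation for this assay therefore rests on no direct precedent, and a drop beyond the scatter is possible. Compound 4 is estimated at 65%, with a range from 25% to 95%, the expected step being a number 29.4 percentage points lower from compound 3 to compound 4 (beyond the scatter).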

Compound 4, a percentage reported as inhibition, at one concentration (the size of the read-out at that concentration, not a potency): 58.4%
For compound 4 the middle estimate is 6.6 percentage points above the measured one; low and high end bracket the measured number.
By their numbers in this assay, from the lowest: compound 4; then compounds 1, 3 and 2 (each within the scatter of the next).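

In this assay taking away the whole arm registers as a number 36 percentage points lower from compound 3 to compound 4 (beyond the scatter) and equally as a number 38.2 percentage points lower from compound 2 to compound 4 (beyond the scatter) and as a number 33.2 percentage points lower from compound 1 to compound 4 (beyond the scatter) whichever terminal group the arm carried. The earlier exchanges only showed that the end of the arm could vary without a change beyond the scatter, whereas these steps show that having an arm on this aromatic carbon, between two ring nitrogen atoms, matters far more than what stands at its end, since hydrogen there falls well apart from all three arm-bearing compounds. The arm does not account for all of the effect, however: compound 4 still gives 58.4% so the shared core without any arm retains part of the inhibition at the concentration tested.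

The compounds shown leave open how much of the arm is needed, that is, whether a free sulfanyl group, a methylsulfanyl group or an amine on that carbon would stand with compounds 1, 2 and 3 or with compound 4. Nothing measured here explains the loss, which remains an observation from a single concentration.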